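The source may report more compounds than this note shows. Statements on the series, on what has been measured and on what is new or still open speak of the compounds shown alone.

Among the measured compounds shown here, compound 2, `O=C(NNc1ccccc1)C1CCC(=O)N1S(=O)(=O)c1ccc(Cl)c(Cl)c1`, and compound 1, `NNC(=O)C1CCC(=O)N1S(=O)(=O)c1ccc(Cl)cc1`, are the two measured members of this set. In a functional assay on the whole organism with Mus musculus as the target, at a dose of 50 mg/kg by the intraperitoneal route (on this read-out higher numbers stand for more inhibition at the one dose given (going by the name of the read-out) and lower numbers for less inhibition), compound 1 gives 61.1%, and compound 2 gives 57.7%, the lowest of the two numbers but within the scatter of compound 1. Compound 3, `NNC(=O)C1CCC(=O)N1S(=O)(=O)c1ccc(Cl)c(Cl)c1`, carries hydrogen in place of phenyl on an amine nitrogen. For the measured compounds named here, no measured pair shows the effect of such a change, so the step from compound 2 to compound 3 is expected to be a number 2.3 percentage points higher from compound 2 to compound 3 (within the scatter), within the scatter. On that basis compound 3 is expected to give 60% in this assay, between 45% and 75%.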

Compound 3, a percentage reported as inhibition, in the whole organism at one dose (the size of the read-out at that dose, not a potency): 58.3%
Beside the measured number, compound 3's estimate is 1.7 percentage points above it, within the range that was stated.
By their numbers in this assay, from the lowest: compounds 2, 3 and 1 (each within the scatter of the next).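

In this assay, hydrogen in place of phenyl on the amine nitrogen gives a number 0.6 percentage points higher from compound 2 to compound 3 (within the scatter), so at this position the phenyl can go with no change beyond the scatter. Chloro in place of hydrogen on an aromatic carbon gives a number 2.8 percentage points lower from compound 1 to compound 3 (within the scatter), the first reading of that change, and it also stays within the scatter. As far as these compounds go, whether a methyl or acetyl group on that nitrogen, or a methoxy group in place of the added chloro, would move the number beyond the scatter stays open. No measured evidence bears on the reason for either step.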